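A Trifluoromethyl Step at the Limit of Tolerance

The source may report more compounds than this note shows. Statements on the series, on what has been measured and on what is new or still open speak of the compounds shown alone.

In an ADME assay on MDBK cells (Bos taurus) for cytotoxicity (a lower number here means that less compound is tolerated, a higher number that more compound is tolerated), compound 1 (`c1ccc(Cn2ccc3nc(-c4ccccc4)nc-3c2)cc1`) gives > 100000 nM, which is a limit and not a number. Compound 2 (`COc1ccccc1Cn1ccc2nc(-c3ccccc3)nc-2c1`) gives > 100000 nM, also a limit. Compound 3 (`N#Cc1ccc(Cn2ccc3nc(-c4ccccc4)nc-3c2)cc1`) gives > 100000 nM, again a limit. Compound 4 (`FC(F)(F)c1cccc(Cn2ccc3nc(-c4ccccc4)nc-3c2)c1`) differs from compound 1 by trifluoromethyl in place of hydrogen on an aromatic carbon, with trifluoromethyl in place of hydrogen on an aromatic carbon. The closest measured changes are a step that the two limits leave unreadable from compound 1 to compound 2 and a step that the two limits leave unreadable from compound 1 to compound 3, while a step that the two limits leave unreadable from compound 2 to compound 3 also has no readable size. All three measured compounds share (the limit of > 100000 nM in this assay, at which 3 of the 3 values shown sit), so no fall in this assay is expected. The expected change is a number no higher from compound 1 to compound 4 (the limit leaves the size open), with none beyond the scatter. The estimate for compound 4 is 100000 nM, within an expected range of 40000 nM to 200000 nM.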

Compound 4, half-maximal cytotoxic concentration: 98000 nM
For compound 4 the middle estimate is 1.0-fold (0.01 log units) above the measured one, and the stated range covers the measured number.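

Compound 4 is the only compound shown that gives a number rather than a limit in this assay: 98000 nM. On an aromatic carbon, meta to a large group, trifluoromethyl in place of hydrogen gives an at least 1.0-fold lower number from compound 1 to compound 4 (0.00 log units; that floor lies within the scatter), so this change shows no fall beyond the scatter. The series still sits largely at one mark: the limit of > 100000 nM in this assay, at which 3 of the 4 values shown sit.

On these data alone, the steps among compound 1, compound 2 and compound 3 cannot be read, and the true size of the new step stays open. As far as these compounds go, how an amine or a carboxylic acid at this position would fare in this assay also stays open.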